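This account rests on a few compounds, and the source may have more. Where it says the series, first, only, none or still open, it means among the compounds named here.

Working notes on the series. Compound 1 `Clc1ccc(OC(CCn2ccnc2)c2ccccc2)c(Cl)c1` stands in a functional assay on K562 cells (Homo sapiens) for cytotoxicity (a higher number here means that more compound is tolerated, a lower number that less compound is tolerated), at 96700 nM, the lower of the two numbers in hand. Compound 2 `Clc1ccc(OC(CCn2ccnc2)c2ccccc2)cc1` gives 221000 nM in this assay. Within the data shown here, the single measured step, a 2.3-fold higher number from compound 1 to compound 2 (0.36 log units; beyond the scatter), corresponds to hydrogen in place of chloro on an aromatic carbon. Compound 3 `Clc1ccc(C(CCn2ccnc2)Oc2ccc(Cl)cc2Cl)cc1` carries the change (chloro in place of hydrogen on an aromatic carbon); cut one bond further out it reads phenyl to 4-chlorophenyl, the chloro sitting para to a large group. This is the mirror image of the measured step, a chloro entering rather than leaving, so the direction should reverse. With only the modest step from compound 1 to compound 2 as a guide, a modest move toward a lower number is expected for compound 3, a 1.9-fold lower number from compound 1 to compound 3 (0.29 log units; within the scatter). Compound 3 is therefore estimated at 50000 nM in this assay, with a range from 22000 nM to 115000 nM.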

Compound 3, half-maximal cytotoxic concentration: 54000 nM
Compound 3: middle estimate off by 1.1-fold (0.03 log units), on the low side; the range from low to high includes it.
By their numbers in this assay, from the lowest: compounds 3 and 1 (each within the scatter of the next); then compound 2.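

In this assay, the added chloro, para to a large group, gives a 1.8-fold lower number from compound 1 to compound 3 (0.25 log units; within the scatter), so phenyl to 4-chlorophenyl leaves compound 3 and compound 1 indistinguishable. The earlier step, a 2.3-fold higher number from compound 1 to compound 2 (0.36 log units; beyond the scatter), shows a chloro at another aromatic carbon making a difference beyond the scatter, and that result does not carry over to this position. Nothing in hand bears on the reason for this contrast.

Open, as far as these compounds go, is whether another group at this place, such as methoxy, an amine or a carboxylic acid, would move the number beyond the scatter. Also open, from the compounds shown here alone, is whether this chloro would behave the same way on the core of compound 2, which lacks the chloro lost in the earlier step.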